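From bromo to nitro on the aromatic ring

This account rests on a few compounds, and the source may have more. Where it says the series, first, only, none or still open, it means among the compounds named here.

Compound 1 `Cc1ccc(CN2CCC=C(CCC(=O)NO)C2=O)cc1`: 5000 nM
Compound 2 `O=C(CCC1=CCCN(Cc2ccc(NC(=O)c3ccccc3)cc2)C1=O)NO`: > 10000 nM (a limit of the assay, not a number)
Compound 3 `O=C(CCC1=CCCN(Cc2ccc(Br)cc2)C1=O)NO`: 2480 nM

These values come from a functional assay on ACHN cells (Homo sapiens) for inhibition, read by sulforhodamine B assay; a higher number here means a weaker inhibitor of growth, a lower number a stronger inhibitor of growth. Compound 3 stands level with compound 1, since a 2.0-fold lower number from compound 1 to compound 3 (0.30 log units; within the scatter). It clearly separates from the limit of compound 2, with an at least 4.0-fold lower number from compound 2 to compound 3 (0.60 log units; beyond the scatter).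

The next compound is compound 4 `O=C(CCC1=CCCN(Cc2ccc([N+](=O)[O-])cc2)C1=O)NO`, which has nitro in place of bromo on an aromatic carbon, para to a large group: nitro in place of bromo on an aromatic carbon.

Within the data shown here, no measured step involves nitro, so the closest guides are the other swaps on an aromatic carbon. Going the other way from compound 1, an at least 2.0-fold higher number from compound 1 to compound 2 (0.30 log units; that floor lies within the scatter). Only the swap between benzamido and bromo gave a step beyond the scatter, while the swap between methyl and bromo did not. On that slim evidence, no step beyond the scatter is expected in this assay, though a small rise is possible.

The expected change is a 1.2-fold higher number from compound 3 to compound 4 (0.08 log units; within the scatter).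

For compound 4 the estimated value is 3000 nM, with an expected range from 1200 nM to 7500 nM.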

Compound 4, concentration for 50% growth inhibition: 5210 nM
The estimate for compound 4 lay 1.7-fold (0.24 log units) below the measured number; measured number inside the range.
By their numbers in this assay, from the lowest: compounds 3, 1 and 4 (each within the scatter of the next, the first and the last beyond it). At a limit, above all of these: compound 2.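

In this assay, nitro in place of bromo on this aromatic carbon, para to a large group, gives a 2.1-fold higher number from compound 3 to compound 4 (0.32 log units; beyond the scatter), so a swap that adds no ring can still produce a modest step. Nitro and methyl cannot be told apart, with a 1.0-fold higher number from compound 1 to compound 4 (0.02 log units; within the scatter), and methyl also stays within the scatter of bromo, so only the two ends of this short series separate. Nitro in place of benzamido gives only a floor, an at least 1.9-fold lower number from compound 2 to compound 4 (0.28 log units; that floor lies within the scatter), since the value of compound 2 is a limit of the assay: the limit of > 10000 nM in this assay, at which 1 of the 4 values shown sits.

The compounds shown leave open how an amine, a carboxylic acid or a methoxy group on this carbon would behave in this assay. They also leave open whether a longer chain carrying the same groups would keep this order.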